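Reshuffling the hydroxy side chain: compound 3 to compound 4

A few compounds are considered here, and "the series" means these few. Any claim that something is new, unique, unknown or untested is made for them only; others in the source may bear on it.

Compound 1 `CCCCC(O)CC(=O)O[C@H](CC=C(C)C)C1=CC(=O)c2c(O)ccc(O)c2C1=O`: 45300 nM
Compound 2 `CC(C)=CC[C@@H](OC(=O)CC(C)(O)C(C)C)C1=CC(=O)c2c(O)ccc(O)c2C1=O`: 16900 nM
Compound 3 `CCCC(C)(O)CC(=O)O[C@H](CC=C(C)C)C1=CC(=O)c2c(O)ccc(O)c2C1=O`: 75000 nM

All three values come from a functional assay on DU-145 cells (Homo sapiens) for cytotoxicity, read by MTT assay; on this read-out lower numbers stand for stronger inhibition and higher numbers for weaker inhibition. Compound 3 is not separated from every neighbour: the data show a 1.7-fold higher number from compound 1 to compound 3 (0.22 log units; within the scatter), but also a 4.4-fold higher number from compound 2 to compound 3 (0.65 log units; beyond the scatter). Compound 4 `CCC(O)(CC)CC(=O)O[C@H](CC=C(C)C)C1=CC(=O)c2c(O)ccc(O)c2C1=O` alters only the side chain, with 1-ethyl-1-hydroxypropyl in place of 1-hydroxy-1-methylbutyl on a saturated chain carbon bound to a carbonyl carbon. Those two measured steps also swap one side chain for another, and the larger is only modest. Compound 1 offers the closer guide at 45300 nM, so no step beyond the scatter is expected in this assay, and no direction is clearly favoured. The expected step is a 1.7-fold lower number from compound 3 to compound 4 (0.22 log units; within the scatter). For compound 4 the estimate is 45000 nM, with an expected range of 17000 nM to 100000 nM.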

Compound 4, half-maximal inhibitory concentration: 67000 nM
For compound 4 the middle estimate is 1.5-fold (0.17 log units) below the measured one, and the stated range covers the measured number.
By their numbers in this assay, from the lowest: compound 2; then compounds 1, 4 and 3 (each within the scatter of the next).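

Rearranging the same atoms around the hydroxy-bearing carbon, from 1-hydroxy-1-methylbutyl to 1-ethyl-1-hydroxypropyl, stays within the scatter in this assay (with a 1.1-fold lower number from compound 3 to compound 4 (0.05 log units; within the scatter)), and so does the comparison with the 1-hydroxypentyl chain (with a 1.5-fold higher number from compound 1 to compound 4 (0.17 log units; within the scatter)). The 1-hydroxy-1,2-dimethylpropyl chain remains the one that stands apart here (with a 4.0-fold higher number from compound 2 to compound 4 (0.60 log units; beyond the scatter)). Nothing available accounts for that difference.

Still open, from the compounds shown here alone, is whether an amine in place of the hydroxy group, or a longer chain, would shift the number beyond the scatter.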